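Swapping the Amide Tail on a Shared Quinolone Core

The source may hold more compounds than are shown below. What is called first, only, known or untested is meant among the compounds shown, and "the series" means these compounds.

Of the compounds shown here, two built on the same core have been tested in a functional assay on SUP-B15 cells (Homo sapiens) for antiproliferative activity, with a stated time of 72 h; a higher number here means that more compound is needed for the effect, a lower number that less compound is needed. Compound 1 `COc1ccc(-c2cc(=O)c3c(OC)cc(OC)cc3n2S(=O)(=O)c2ccc(C=O)cc2)cc1` gives only a limit of the assay, > 34400 nM. Compound 2 `COc1cc(OC)c2c(=O)cc(C(=O)Nc3ccc(N4CCN(C)CC4)cc3)[nH]c2c1` likewise gives only a limit, > 19800 nM. Compound 2 therefore stands at the limit of > 19800 nM in this assay, at which 1 of the 2 values shown sits, while the other value shown sits at the limit of > 34400 nM in this assay, at which 1 of the 2 values shown sits; neither is a true number, so no order between the two compounds can be read.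

Compound 3 `COc1cc(OC)c2c(=O)cc(C(=O)Nc3ccc(Oc4cccnc4)cc3)[nH]c2c1` is compound 2 with one change: (pyridin-3-yl)oxy in place of 4-methylpiperazin-1-yl on an aromatic carbon. For the measured compounds named here, no measured step between two numbered values exists here, so no size or direction can be taken from the data. The expectation for the step from compound 2 to compound 3 in this assay is nothing beyond the scatter, that is a step that the limit leaves unreadable from compound 2 to compound 3. Compound 3 is accordingly expected to give about 20000 nM, with a range from 5000 nM to 60000 nM, quite possibly again only as a limit.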

Compound 3, half-maximal effective concentration: > 32100 nM
Compound 3: a limit, no number (the forecaster's own chance of this, stated with the estimate: 70%); middle value at least 1.6-fold (0.20 log units) away from the limit.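

Compound 2 and compound 3 both give only limits, and the step between them, (pyridin-3-yl)oxy in place of 4-methylpiperazin-1-yl, cannot be read. Left open is the true concentration each of the three compounds needs in this assay, and whether this swap changes it at all.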